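The source may hold more compounds than are shown below. What is called first, only, known or untested is meant among the compounds shown, and "the series" means these compounds.

Measured so far in a functional assay on OVCAR-3 cells (Homo sapiens) for cytotoxicity, read by MTT assay, with a stated time of 72 h; a higher number here means a weaker inhibitor, a lower number a stronger inhibitor:
compound 1 `CCCCN(CCCC)c1nc2c(ncn2-c2ccccc2)c(=O)n1-c1ccccc1`: 10000 nM
compound 2 `CC(C)N(c1nc2c(ncn2-c2ccccc2)c(=O)n1-c1ccccc1)C(C)C`: > 100000 nM (a limit of the assay)
compound 3 `CCCCCN(CCCCC)c1nc2c(ncn2-c2ccccc2)c(=O)n1-c1ccc(Cl)cc1`: > 100000 nM (a limit of the assay)

On these data alone, compound 3 thus stands at a limit, and its true value is unknown. Two of the three results sit there, as the limit of > 100000 nM in this assay, at which 2 of the 3 values shown sit, records. Compound 4 `CNc1nc2c(ncn2-c2ccccc2)c(=O)n1-c1ccc(Cl)cc1` differs from compound 3 in one place: methylamino in place of dipentylamino on an aromatic carbon. For the measured compounds named here, the only measured step touching the amine at this position is an at least 10-fold higher number from compound 1 to compound 2 (1.00 log units; beyond the scatter), a swap between two bulky amines that weakened the compound. It does not cover a shrink to a single methyl chain, so no direction is fixed. Because compound 3 gives only the limit > 100000 nM the step is loosely estimated. Compound 4 is expected near 40000 nM, within 8000 nM to 200000 nM. This estimated step is an at least 2.5-fold lower number from compound 3 to compound 4 (0.39 log units; beyond the scatter).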

Compound 4, half-maximal inhibitory concentration: > 100000 nM
Compound 4 ended at the assay's limit; the forecaster's own chance of this, stated with the estimate: 45%; at least 2.5-fold (0.39 log units) between middle value and limit.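

For the compounds shown here, compound 3 and compound 4 both sit at a limit, so no step between them can be read: the limit of > 100000 nM in this assay, at which 3 of the 4 values shown sit. On these data alone, whether methylamino or dipentylamino gives the stronger inhibitor stays open, as the true values of both compounds remain unknown.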